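A few compounds are considered here, and "the series" means these few. Any claim that something is new, unique, unknown or untested is made for them only; others in the source may bear on it.

Measured compounds:
Compound 1 `CCCOc1ccc(C(=O)/C=C/c2ccc(C(=O)O)cc2)cc1`: in an ADME assay on Vero cells (Chlorocebus sabaeus) for cytotoxicity, read by MTT assay, with a stated time of 72 h (a higher number here means that more compound is tolerated, a lower number that less compound is tolerated), compound 1 gives < 10 ug/mL, which is a limit of the assay.
Compound 2 `COC(=O)c1cc(-c2cccc(NC(=O)c3ccc(/C=C/C(=O)c4ccc(Br)cc4)cc3)c2)on1`: in this assay compound 2 gives > 20 ug/mL, also a limit of the assay.
Compound 3 `COC(=O)c1cc(-c2ccc(NC(=O)c3ccc(/C=C/C(=O)c4ccc(Cl)cc4)cc3)cc2)on1`: in this assay compound 3 gives > 80 ug/mL, again a limit of the assay.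

Compound 2 thus stands only at a limit (the limit of > 20 ug/mL in this assay, at which 1 of the 3 values shown sits), and the two other values shown are limits as well the limit of < 10 ug/mL in this assay, at which 1 of the 3 values shown sits (the limit of > 80 ug/mL in this assay, at which 1 of the 3 values shown sits), so no numbered value and no measured step is known among these three. Compound 4 `COC(=O)c1cc(-c2cccc(NC(=O)c3ccc(/C=C/C(=O)c4ccc(OC)c([N+](=O)[O-])c4)cc3)c2)on1` differs from compound 2 in one place: 4-methoxy-3-nitrophenyl in place of 4-bromophenyl on a carbonyl carbon. For the measured compounds named here, with no measured step to lean on, the change expected in this assay is none beyond the scatter, and the read-out is expected to come back as a limit once more. Compound 4 is estimated at 30 ug/mL, with a range from 15 ug/mL to 80 ug/mL. The step from compound 2 to compound 4 is accordingly expected to be a step that the limit leaves unreadable from compound 2 to compound 4.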

Compound 4, half-maximal cytotoxic concentration: > 40 ug/mL
Compound 4: only a limit was reported; the forecaster's own chance of this, stated with the estimate: 70%; middle value at least 1.3-fold (0.12 log units) away from the limit.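

For the compounds shown here, compound 2 and compound 4 are both reported only as limits in this assay, so no step between them can be read. The compounds shown leave open whether 4-methoxy-3-nitrophenyl in place of 4-bromophenyl changes the tolerated concentration at all.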